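The compounds below may be only part of what the source reports. "The series", "measured", "known", "first", "only" and "open" are said of these compounds alone.

Measured in an in vivo functional assay on the whole organism (MDA-MB-435 cells, Homo sapiens) for antiproliferative activity; a higher number here means a weaker inhibitor, a lower number a stronger inhibitor:
- compound 1 `CO[C@@H](C(=O)NC1CC[C@@H](OC(=O)c2ccccc2)CNC1=O)[C@H](O)[C@@H](O)[C@H](O)/C=C/C(C)(C)C` gives 370 nM
- compound 2 `CO[C@@H](C(=O)NC1CC[C@@H](OC(=O)CC2CCCCC2)CNC1=O)[C@H](O)[C@@H](O)[C@H](O)/C=C/C(C)(C)C` gives 60 nM
- compound 3 `CO[C@@H](C(=O)NC1CC[C@@H](OC(=O)C2CCCCC2)CNC1=O)[C@H](O)[C@@H](O)[C@H](O)/C=C/C(C)(C)C` gives 4 nM

Compound 3 has the lowest number of the three, and its steps to both others lie beyond the scatter. Compound 4 `CO[C@@H](C(=O)NC1CC[C@@H](OC(=O)/C=C/c2ccccc2)CNC1=O)[C@H](O)[C@@H](O)[C@H](O)/C=C/C(C)(C)C` carries 2-phenylethenyl in place of cyclohexyl on a carbonyl carbon. Among the compounds with values here, no measured compound holds this group, so the comparison is indirect. Compound 1 also has an aromatic ring here, and a 93-fold lower number from compound 1 to compound 3 (1.97 log units; beyond the scatter) is large. The other step ending at cyclohexyl, a 15-fold lower number from compound 2 to compound 3 (1.18 log units; beyond the scatter), is large too. On these two steps, a large move to a higher number is expected in this assay. The expected step is a 25-fold higher number from compound 3 to compound 4 (1.40 log units; beyond the scatter). For compound 4 the estimated value is 100 nM, with an expected range from 15 nM to 600 nM.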

Compound 4, half-maximal inhibitory concentration: 20 nM
Compound 4: middle estimate off by 5.0-fold (0.70 log units), on the high side, within the range that was stated.
By their numbers in this assay, from the lowest: compound 3; then compound 4; then compound 2; then compound 1.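

In this assay, an aromatic ring on this carbonyl carbon is compatible with a low number: replacing cyclohexyl with 2-phenylethenyl gives only a 5.0-fold higher number from compound 3 to compound 4 (0.70 log units; beyond the scatter), while replacing cyclohexylmethyl gives a 3.0-fold lower number from compound 2 to compound 4 (0.48 log units; beyond the scatter). Among these four compounds, the weak result belongs to phenyl rather than to every aromatic group, as replacing phenyl with 2-phenylethenyl gives a 19-fold lower number from compound 1 to compound 4 (1.27 log units; beyond the scatter). No available evidence accounts for this order.

Still open, from the compounds shown here alone, is how 2-phenylethyl would compare, which would separate the contribution of the double bond from that of the longer chain. Also open, going by these compounds, is whether a ring carrying an amine is tolerated here.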